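This account rests on a few compounds, and the source may have more. Where it says the series, first, only, none or still open, it means among the compounds named here.

Compound 3 `CNCc1cn(S(=O)(=O)c2cccc(OC)n2)c(-c2cccnc2F)c1F` is the reference point here. In a functional assay on the whole organism (strain Jcl:Sprague-Dawley) for inhibition, with Rattus norvegicus as the target, with stated times of 3 min and 3 h, at a dose of 1 mg/kg by the intravenous route (a higher number here means more inhibition at the dose given (going by the name of the read-out), a lower number less inhibition), compound 3 gives 98%, the highest of the three numbers recorded; it sits a number 23 percentage points higher from compound 1 to compound 3 (beyond the scatter) and, against compound 2, only a number 3 percentage points higher from compound 2 to compound 3 (within the scatter). Compound 1 `CNCc1cn(S(=O)(=O)c2ccco2)c(-c2cccnc2F)c1F` gives 75% in this assay, and compound 2 `CNCc1cn(S(=O)(=O)c2ccoc2)c(-c2cccnc2F)c1F` gives 95%, the pair being separated by a number 20 percentage points higher from compound 1 to compound 2 (beyond the scatter).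

Compound 4 `CNCc1cn(S(=O)(=O)c2ncccc2C)c(-c2cccnc2F)c1F` has not yet been measured. It differs from compound 3 in one place: 3-methylpyridin-2-yl in place of 6-methoxypyridin-2-yl on a sulfonyl sulfur.

Going by the values given here, none of the measured steps exchanges one pyridinyl for another on the sulfonyl sulfur, so no step bears directly on this change. What the numbers do show is that the group on the sulfonyl sulfur matters at the low end, since furan-2-yl in compound 1 falls short of both other groups by a modest margin, whereas furan-3-yl and 6-methoxypyridin-2-yl, in compound 2 and compound 3, lie within the scatter of each other. On that basis compound 4 is expected to stay near compound 3, with a step of a number 8 percentage points lower from compound 3 to compound 4 (within the scatter) that is likely to fall within the scatter, a modest drop being the main risk because of a number 23 percentage points higher from compound 1 to compound 3 (beyond the scatter) seen when the ring on the sulfonyl sulfur was altered. The estimate for compound 4 in this assay is 90%, with a range from 72% to 99%.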

Compound 4, a percentage reported as inhibition, in the whole organism at one dose (the size of the read-out at that dose, not a potency): 54%
Beside the measured number, compound 4's estimate is 36 percentage points above it, outside the stated range (below it).
By their numbers in this assay, from the lowest: compound 4; then compound 1; then compounds 2 and 3 (each within the scatter of the next).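

With 3-methylpyridin-2-yl on the sulfonyl sulfur, this assay shows that this position can lose far more than the two furans suggested: the change gives a number 44 percentage points lower from compound 3 to compound 4 (beyond the scatter) and, against the better furan, a number 41 percentage points lower from compound 2 to compound 4 (beyond the scatter) as well. Furan-2-yl had marked the low end so far, yet the new group also falls under it, with a number 21 percentage points lower from compound 1 to compound 4 (beyond the scatter) and compound 4 is therefore the lowest of the four compounds. Since compound 3 and compound 4 both carry a pyridine ring on the sulfonyl sulfur, that ring alone does not secure a high number, and the substituted pyridine ring is clearly not interchangeable here; nothing available accounts for the drop.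

The two pyridinyl groups differ in both the substituent and where it sits, so the compounds shown cannot say whether the fall goes with the methyl group, with the absence of methoxy or with the place of substitution. Unsubstituted pyridin-2-yl, 6-methylpyridin-2-yl and 3-methoxypyridin-2-yl would separate these readings, and how they would fall remains open.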